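Aryl change on the shared core: compound 2 to compound 3

A few compounds are considered here, and "the series" means these few. Any claim that something is new, unique, unknown or untested is made for them only; others in the source may bear on it.

- compound 1 `C[C@H]1CC[C@@H]2[C@@H](OC(=O)[C@]23CC(c2ccc(Cl)cc2)=NO3)[C@]2(C)C(=O)C=C[C@@]12O` gives 43000 nM
- compound 2 `COc1ccc(C2=NO[C@]3(C2)C(=O)O[C@@H]2[C@H]3CC[C@H](C)[C@]3(O)C=CC(=O)[C@@]23C)cc1OC` gives 84000 nM

Among the compounds with values here, both values come from a functional assay on DU-145 cells (Homo sapiens) for cytotoxicity, read by sulforhodamine B assay, with a stated time of 48 h (on this read-out lower numbers stand for stronger inhibition and higher numbers for weaker inhibition), and lie within the scatter of each other, so compound 2 cannot be ranked against compound 1, its only measured neighbour. Within the data shown here, the one measured step is a 2.0-fold higher number from compound 1 to compound 2 (0.29 log units; within the scatter) and it comes with 3,4-dimethoxyphenyl in place of 4-chlorophenyl on a carbon with a double bond to nitrogen.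

Next is compound 3 `Cc1ccc(C2=NO[C@]3(C2)C(=O)O[C@@H]2[C@H]3CC[C@H](C)[C@]3(O)C=CC(=O)[C@@]23C)cc1` which differs from compound 2 at that same carbon, with 4-methylphenyl in place of 3,4-dimethoxyphenyl on a carbon with a double bond to nitrogen and no other change. Among the measured compounds shown here, the single earlier step at this place is the only guide, and it stayed within the scatter. Two data points are a thin basis, but no step beyond the scatter is expected in this assay in either direction. The expected step is a 1.4-fold lower number from compound 2 to compound 3 (0.15 log units; within the scatter) and it remains an estimate. The estimate for compound 3 is 60000 nM with an expected range from 28000 nM to 120000 nM on present evidence.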

Compound 3, half-maximal inhibitory concentration: 14000 nM
The estimate for compound 3 lay 4.3-fold (0.63 log units) above the measured number; the measured number lies below the stated range.
By their numbers in this assay, from the lowest: compound 3; then compounds 1 and 2 (each within the scatter of the next).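

Within the data shown here, the aryl group on the carbon with a double bond to nitrogen does move the read-out in this assay: the step with 4-methylphenyl in place of 3,4-dimethoxyphenyl is a 6.0-fold lower number from compound 2 to compound 3 (0.78 log units; beyond the scatter), the first step to clear the scatter, whereas the earlier change at this place did not. The second comparison, with methyl in place of chloro on an aromatic carbon, is a 3.1-fold lower number from compound 1 to compound 3 (0.49 log units; beyond the scatter), so a change of one substituent on the aryl group is enough to separate compounds here and the position is not flat as the first pair suggested. Among these three, compound 3 is the most potent, with compound 3 at 14000 nM, while compound 1 and compound 2 remain unranked against each other and the sensitivity rests on this one compound.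

Open, going by these compounds, is whether the methyl is itself the useful feature, which unsubstituted phenyl, 4-ethylphenyl as a longer chain, or 4-aminophenyl with its amine would help to settle, and whether the ranking holds beyond this single cell assay. No supporting data bear on why compound 3 separates from the other two.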